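This account rests on a few compounds, and the source may have more. Where it says the series, first, only, none or still open, it means among the compounds named here.

In an ADME assay on the whole organism (strain Wistar) for pharmacokinetics, with Rattus norvegicus as the target, given by the intravenous route (a higher number here means faster removal of the compound, a lower number slower removal), compound 1 (`Cc1cn([C@H]2CCCN([C@H](CC(C)C)c3ccc(C(=O)O)c(Oc4cccc(Cl)c4)c3F)C2)c(=O)[nH]c1=O`) stands highest at 84 mL/min/kg and compound 2 (`Cc1cn([C@H]2CCCN([C@@H](CC(C)C)c3ccc(C(=O)O)c(Oc4cccc(Cl)c4)c3F)C2)c(=O)[nH]c1=O`) lies lower at 38 mL/min/kg. Among the measured compounds shown here, the only measured step (a 2.2-fold lower number from compound 1 to compound 2 (0.34 log units; beyond the scatter)) is modest, and it goes with the fact that compounds 1 and 2 differ only in the configuration as drawn as its sole structural difference. Compound 3 (`CCC[C@H](c1ccc(C(=O)O)c(Oc2cccc(Cl)c2)c1F)N1CCC[C@H](n2cc(C)c(=O)[nH]c2=O)C1`) differs from compound 1 in another way (hydrogen in place of methyl on a saturated chain carbon bound to two saturated chain carbons): hydrogen in place of methyl on a saturated chain carbon bound to two saturated chain carbons, which turns isobutyl into propyl. For the measured compounds named here, no measured step covers this kind of change, so the configurational step bears on it only indirectly, as a guide to how far numbers can move. No step beyond the scatter is expected in this assay, and the estimated step is small (a 1.2-fold lower number from compound 1 to compound 3 (0.07 log units; within the scatter)). For compound 3 the expected clearance is 72 mL/min/kg, with an estimated range from 38 mL/min/kg to 125 mL/min/kg.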

Compound 3, clearance: 64 mL/min/kg
For compound 3 the middle estimate is 1.1-fold (0.05 log units) above the measured one; the range from low to high includes it.
By their numbers in this assay, from the lowest: compounds 2, 3 and 1 (each within the scatter of the next, the first and the last beyond it).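

In this assay, the change from isobutyl to propyl, with hydrogen in place of methyl on a saturated chain carbon bound to two saturated chain carbons, gives a 1.3-fold lower number from compound 1 to compound 3 (0.12 log units; within the scatter). Removing this methyl therefore leaves clearance within the scatter, whereas the configurational change gives a 2.2-fold lower number from compound 1 to compound 2 (0.34 log units; beyond the scatter), so among the steps shown only the latter can be told from repeat-measurement noise. Nothing at hand gives a measured property that bears on the chain change.

As far as these compounds go, it remains open whether a longer chain such as pentyl, or a chain carrying an amine or a hydroxyl group, would keep clearance in the same range. From the compounds shown here alone, it is also open whether the propyl chain with the opposite configuration as drawn would repeat the configurational step seen with isobutyl.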